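A few compounds are considered here, and "the series" means these few. Any claim that something is new, unique, unknown or untested is made for them only; others in the source may bear on it.

Compound 1 `O=C(Nc1ccc(-c2noc(-c3cccc(NS(=O)(=O)c4cccc(Cl)c4)c3)n2)c(Cl)c1)c1cccnc1` and compound 2 `COc1cccc(NC(=O)Nc2cccc(-c3nc(-c4ccc(NC(=O)c5cccnc5)cc4Cl)no3)c2)c1` share a core and differ only on an aromatic nitrogen, where the (3-chlorophenyl)sulfonyl of compound 1 gives way to the (3-methoxyphenyl)carbamoyl of compound 2. In a functional assay on MDA-MB-231 cells (Homo sapiens) for antiproliferative activity, read by MTT assay, with a stated time of 72 h (a higher number here means a weaker inhibitor, a lower number a stronger inhibitor), compound 1 returns only a limit, > 10000 nM. In this assay compound 2 gives 6700 nM, the only number shown. The step of an at least 1.4-fold lower number from compound 1 to compound 2 (0.17 log units; that floor lies within the scatter) is set by the limit of > 10000 nM in this assay, at which 1 of the 2 values shown sits, so its true size is open.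

Compound 3 `COc1ccc(NC(=O)Nc2cccc(-c3nc(-c4ccc(NC(=O)c5cccnc5)cc4Cl)no3)c2)cc1` is not yet measured. It differs from compound 2 only in the position of the methoxy group: 4-methoxyphenyl in place of 3-methoxyphenyl on an amide-type nitrogen. Going by the values given here, no measured pair bears on that shift; the one measured step concerns a different part of the molecule and is bounded by a limit.

With nothing to point either way, compound 3 is expected to sit near compound 2 in this assay, a step of a 1.0-fold higher number from compound 2 to compound 3 (0.02 log units; within the scatter) that stays within the scatter. The estimate for compound 3 is 7000 nM, between 3000 nM and 20000 nM.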

Compound 3, half-maximal inhibitory concentration: 3000 nM
Estimate against measurement, compound 3: 2.3-fold (0.37 log units) above; the range from low to high includes it.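

In this assay, the position of the methoxy group on this ring matters: a 2.2-fold lower number from compound 2 to compound 3 (0.35 log units; beyond the scatter), although 3-methoxyphenyl and 4-methoxyphenyl carry the same atoms and the same counted features. This is the first step among the compounds shown with a measured size on both sides, and it lies beyond the scatter, which the floor of the step from compound 1 to compound 2 did not. With the 4-methoxyphenyl in the carbamoyl group, the comparison with the (3-chlorophenyl)sulfonyl of compound 1 also clears the scatter, an at least 3.3-fold lower number from compound 1 to compound 3 (0.52 log units; beyond the scatter), but that size is only a floor because one end of the step is a limit: the limit of > 10000 nM in this assay, at which 1 of the 3 values shown sits.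

The compounds shown leave open whether the change in this assay depends on the methoxy group itself or on any group at that place, a question that 4-ethoxyphenyl, 4-chlorophenyl or plain phenyl on the same amide-type nitrogen would address. They also leave open how much of the step from compound 1 comes from the carbamoyl in place of the sulfonyl and how much from the ring, which a (4-methoxyphenyl)sulfonyl group would help to separate.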